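The compounds below may be only part of what the source reports. "The series", "measured", "known", "first", "only" and "open" are said of these compounds alone.

In a functional assay on COLO 205 cells (Homo sapiens) for inhibition, read by sulforhodamine B assay, with a stated time of 48 h, tested at 50 uM (on this read-out higher numbers stand for more inhibition of growth at the one concentration tested and lower numbers for less inhibition of growth), compound 2 `COc1ccc(/C=C/C(=O)/C=C/c2ccc(OCc3cn(CCCCCOc4cc(=O)oc5ccccc45)nn3)c(OC)c2)cc1` gives 30%, within the scatter of compound 1 `COc1cccc(/C=C/C(=O)/C=C/c2ccc(OCc3cn(CCCCCOc4cc(=O)oc5ccccc45)nn3)c(OC)c2)c1` at 34%. Compound 3 `COc1cc(/C=C/C(=O)/C=C/c2cc(OC)c(OC)c(OC)c2)ccc1OCc1cn(CCCCCOc2cc(=O)oc3ccccc23)nn1` follows from compound 2 as 3,4,5-trimethoxyphenyl in place of 4-methoxyphenyl on a double-bonded chain carbon bound to a double-bonded chain carbon, with 3,4,5-trimethoxyphenyl in place of 4-methoxyphenyl on a double-bonded chain carbon bound to a double-bonded chain carbon. Among the compounds with values here, the only measured step at this place, 4-methoxyphenyl in place of 3-methoxyphenyl, is a number 4 percentage points lower from compound 1 to compound 2 (within the scatter). It stays within the scatter and involves no added methoxy group, so it offers weak guidance, and no step beyond the scatter is expected. The expected change is a number 3 percentage points higher from compound 2 to compound 3 (within the scatter). Compound 3 is estimated at 33%, with an expected range of 20% to 50%.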

Compound 3, percent growth inhibition at one concentration: 51%
Estimate against measurement, compound 3: 18 percentage points below; measured number above the stated range.
By their numbers in this assay, from the lowest: compounds 2 and 1 (each within the scatter of the next); then compound 3.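

In this assay this place on a double-bonded chain carbon bound to a double-bonded chain carbon now shows a real response: 3,4,5-trimethoxyphenyl gives a number 21 percentage points higher from compound 2 to compound 3 (beyond the scatter) and also a number 17 percentage points higher from compound 1 to compound 3 (beyond the scatter). The two single-methoxy groups remain within the scatter of each other, so among these compounds only the 3,4,5-trimethoxyphenyl group stands apart. Nothing available explains this gain.

On these data alone, whether all three methoxy groups are needed remains open, and 3,4-dimethoxyphenyl would test that. As far as these compounds go, it is also open whether a 4-dimethylaminophenyl group at this place would match the gain.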